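The compounds below may be only part of what the source reports. "The series", "measured", "known", "first", "only" and "open" are said of these compounds alone.

Compound 1 `CC(O)c1cn(Cc2cc(=O)oc3cc(O)ccc23)nn1` and compound 2 `CCCCc1ccc(-c2cn(Cc3cc(=O)oc4cc(O)ccc34)nn2)cc1` share one core and differ in the group attached to it. In a functional assay on CFPAC-1 cells (Homo sapiens) for inhibition, read by MTT assay, with a stated time of 72 h (a higher number here means a weaker inhibitor, a lower number a stronger inhibitor), compound 1 gives only a limit of > 100000 nM, not a measured number. In this assay compound 2 gives 69800 nM. Among the two values shown, that of compound 2 is the only actual number. The other value, that of compound 1, is the limit of > 100000 nM in this assay, at which 1 of the 2 values shown sits. Within the data shown here, compound 2 therefore stands alone as the one compound with a measured potency, with nothing to rank it against except that limit.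

Compound 3 `CCCC1CCC(c2ccc(-c3cn(Cc4cc(=O)oc5cc(O)ccc45)nn3)cc2)CC1` differs from compound 2 in one place: 4-propylcyclohexyl in place of butyl on an aromatic carbon. Among the measured compounds shown here, no step between two measured compounds matches this change, so no measured step can serve as a guide, and the expectation rests on compound 2 alone. The step from compound 2 to compound 3 is expected to be small, of about a 1.7-fold lower number from compound 2 to compound 3 (0.24 log units; within the scatter), leaning toward somewhat stronger inhibition but staying close to the usual scatter. Compound 3 is therefore expected to give about 40000 nM in this assay, within a range from 10000 nM to 150000 nM.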

Compound 3, half-maximal inhibitory concentration: 52800 nM
For compound 3 the middle estimate is 1.3-fold (0.12 log units) below the measured one; low and high end bracket the measured number.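

In this assay the swap of butyl for 4-propylcyclohexyl gives a 1.3-fold lower number from compound 2 to compound 3 (0.12 log units; within the scatter) and so leaves the two compounds indistinguishable. The new information concerns this position, on an aromatic carbon para to a large group: going from 4 heavy atoms to 9 heavy atoms, and adding a six-membered non-aromatic ring of carbon only, leaves the reading within the normal spread of repeat measurements. Compound 1 still offers only a limit and not a number, so it gives no measured point to set beside these two: the limit of > 100000 nM in this assay, at which 1 of the 3 values shown sits.

Going by these compounds, both groups compared here contain carbon only and have no hydrogen-bond donors or acceptors, so what an amine or a carboxylic acid would do at the same place remains open. On these data alone, whether a shorter chain such as ethyl, or a phenyl ring in place of the cyclohexyl ring, would read the same is also open, and one step between two compounds cannot establish a trend.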